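The source may report more compounds than this note shows. Statements on the series, on what has been measured and on what is new or still open speak of the compounds shown alone.

Measured compounds:
compound 1 `O=C(O)CCC/C=C\C[C@H]1[C@@H]2CCC(C2)[C@@H]1NS(=O)(=O)c1ccc(O)cc1`, 500 nM
compound 2 `CS(=O)(=O)N[C@H]1C2CC[C@H](C2)[C@@H]1C/C=C\CCCC(=O)O`, 640000 nM

In a functional assay (plasma) for inhibition, with Oryctolagus cuniculus as the target (on this read-out lower numbers stand for stronger inhibition and higher numbers for weaker inhibition), compound 2 gives 640000 nM, the highest of the two numbers; the nearest is compound 1, which gives 500 nM. Compound 3 `O=C(O)CCC/C=C\C[C@H]1[C@@H]2CCC(C2)[C@@H]1NS(=O)(=O)c1ccc(Cl)cc1` has not yet been measured. It differs from compound 2 in one place: 4-chlorophenyl in place of methyl on a sulfonyl sulfur. Within the data shown here, one measured step bears on this change, and it runs the other way: a 1300-fold higher number from compound 1 to compound 2 (3.11 log units; beyond the scatter), a large step well beyond the scatter. Returning a six-membered aromatic ring to the sulfonyl sulfur, now carrying a chlorine where compound 1 carries a hydroxyl, is therefore expected to move the number strongly down, close to where compound 1 stands, with some uncertainty about how far the 4-chlorophenyl matches the 4-hydroxyphenyl. The expected step is a 1300-fold lower number from compound 2 to compound 3 (3.11 log units; beyond the scatter). Compound 3 is estimated to give about 500 nM, within a range from 80 nM to 3000 nM.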

Compound 3, half-maximal inhibitory concentration: 300 nM
Compound 3: middle estimate off by 1.7-fold (0.22 log units), on the high side, and the stated range covers the measured number.
By their numbers in this assay, from the lowest: compounds 3 and 1 (each within the scatter of the next); then compound 2.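

In this assay, 4-chlorophenyl in place of methyl on the sulfonyl sulfur gives a 2100-fold lower number from compound 2 to compound 3 (3.33 log units; beyond the scatter) and thus shows that the large gap first seen with compound 1 is not tied to the 4-hydroxyphenyl alone. Chloro in place of hydroxy on the aromatic carbon gives a 1.7-fold lower number from compound 1 to compound 3 (0.22 log units; within the scatter) and leaves compound 1 and compound 3 indistinguishable on this read-out, so the hydroxyl is not required for a number in this range. No measurement is available to explain these results.

On these data alone, it remains open whether a plain phenyl or a saturated ring such as cyclohexyl on the sulfonyl sulfur would give a similar number. As far as these compounds go, it also remains open how a methoxy group or an amine would read in place of the chloro.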